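Changing the Outer Ring on the Amide-Type Nitrogen

This account rests on a few compounds, and the source may have more. Where it says the series, first, only, none or still open, it means among the compounds named here.

Of the compounds shown here, three built on a shared core have been tested in a functional assay on A549 cells (Homo sapiens) for antiproliferative activity, read by MTT assay; on this read-out higher numbers stand for weaker inhibition and lower numbers for stronger inhibition. Compound 1 `O=C(Nc1cccc(CNc2ncnc3ccccc23)c1)Nc1ccccc1Cl` gives 18000 nM in this assay. Compound 2 `O=C(Nc1ccc([N+](=O)[O-])cc1)Nc1cccc(CNc2ncnc3ccccc23)c1` reaches only > 50000 nM in this assay, which is a limit of the assay rather than a number. Compound 3 `COc1cc2ncnc(NCc3cccc(NC(=O)Nc4ccccc4C)c3)c2cc1OC` gives 21400 nM in this assay, the higher of the two real numbers, although its gap to compound 1 lies within the scatter, so the two cannot be told apart.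

Compound 4 `COc1ccc(NC(=O)Nc2cccc(CNc3ncnc4cc(OC)c(OC)cc34)c2)cc1` differs from compound 3 in one place: 4-methoxyphenyl in place of 2-methylphenyl on an amide-type nitrogen. Among the compounds with values here, the only measured step at the same position is an at least 2.7-fold higher number from compound 1 to compound 2 (0.44 log units; beyond the scatter), where exchanging the group on that nitrogen weakened inhibition at least modestly and ended at the limit (the limit of > 50000 nM in this assay, at which 1 of the 3 values shown sits). That step involved other groups, so it gives only loose guidance, but it shows that changes at this position have not so far improved inhibition. For compound 4 the expected step is a 1.4-fold higher number from compound 3 to compound 4 (0.15 log units; within the scatter), a small weakening or no change beyond the scatter. Compound 4 is therefore estimated at 30000 nM in this assay, with a range from 12000 nM to 60000 nM.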

Compound 4, half-maximal inhibitory concentration: 24500 nM
Estimate against measurement, compound 4: 1.2-fold (0.09 log units) above; the measured number falls inside the stated range.
By their numbers in this assay, from the lowest: compounds 1, 3 and 4 (each within the scatter of the next). At a limit, above all of these: compound 2.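

Exchanging 2-methylphenyl for 4-methoxyphenyl on the amide-type nitrogen gives a 1.1-fold higher number from compound 3 to compound 4 (0.06 log units; within the scatter) in this assay, so compound 3 and compound 4 cannot be told apart. This shows that a change of the outer ring at this position does not always shift the number beyond the scatter, and that adding the oxygen of the methoxy group, with its hydrogen-bond acceptor, leaves no readable mark here. Compound 2 remains the only compound whose value is a limit rather than a number, so the one clear change at this position still ends there: the limit of > 50000 nM in this assay, at which 1 of the 4 values shown sits.

This single step swaps both the group and its numbered place on the ring, from 2-methylphenyl to 4-methoxyphenyl, so it cannot show what either swap does alone, and the shown compounds cannot separate these effects without 2-methoxyphenyl or 4-methylphenyl at the same nitrogen. From the compounds shown here alone, it also remains open whether a very different outer group, such as an amine or a carboxylic acid on that ring, would give stronger inhibition than the values seen so far.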